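The compounds below may be only part of what the source reports. "The series", "measured", "known", "first", "only" and "open" are said of these compounds alone.

Measured compounds:
- compound 1 `CC(C)/C=C/C(=O)Nc1ccn([C@H]2CC[C@H](O[C@H]3O[C@H](C)[C@@H](N(C)C)[C@H](O)[C@H]3O)[C@@H](C)O2)c(=O)n1`: 780 nM
- compound 2 `CCC(C)/C=C/C(=O)Nc1ccn([C@H]2CC[C@H](O[C@H]3O[C@H](C)[C@@H](N(C)C)[C@H](O)[C@H]3O)[C@@H](C)O2)c(=O)n1`: 890 nM
- compound 3 `CC(C)C(=O)Nc1ccn([C@H]2CC[C@H](O)[C@@H](C)O2)c(=O)n1`: > 20000 nM

In a functional assay on HCT-116 cells (Homo sapiens) for cytotoxicity, read by sulforhodamine B assay, with a stated time of 24 h (on this read-out higher numbers stand for weaker inhibition and lower numbers for stronger inhibition), compound 1 gives 780 nM and compound 2 gives 890 nM. For compound 3 the value in this assay is a limit only, > 20000 nM, reached by the limit of > 20000 nM in this assay, at which 1 of the 3 values shown sits. The change hydrogen in place of methyl on a saturated chain carbon, two bonds along the chain from a double-bonded chain carbon gives a 1.1-fold lower number from compound 2 to compound 1 (0.06 log units; within the scatter). How the core of compound 3 differs from that of compound 2 is not broken down here. For the measured compounds named here, compound 4 `CCC(=O)Nc1ccn([C@H]2CC[C@H](O)[C@@H](C)O2)c(=O)n1` is not yet measured; it differs from compound 3 by hydrogen in place of methyl on a saturated chain carbon bound to a carbonyl carbon and a saturated chain carbon, the same kind of change as the one from compound 2 to compound 1, but around a different place: here the saturated chain carbon is bound to a carbonyl carbon and a saturated chain carbon, there it sits two bonds along the chain from a double-bonded chain carbon. In this assay the step from compound 3 to compound 4 is expected to be a step that the limit leaves unreadable from compound 3 to compound 4, set beside a 1.1-fold lower number from compound 2 to compound 1 (0.06 log units; within the scatter), which rests on the small size of that measured step and on compound 3 sitting at > 20000 nM, the limit named in the limit of > 20000 nM in this assay, at which 1 of the 3 values shown sits. Compound 4 is therefore estimated at 30000 nM, most likely reported again only as a limit.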

Compound 4, half-maximal inhibitory concentration: > 20000 nM
Compound 4 gave a limit, no number; the forecaster's own chance of this, stated with the estimate: 85%; the middle value does not contradict the limit.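

In this assay compound 3 is a limit only, > 20000 nM. Compound 4 is likewise a limit only, > 20000 nM. No step from compound 3 to compound 4 can therefore be read, with both compounds at the same limit: the limit of > 20000 nM in this assay, at which 2 of the 4 values shown sit.

The compounds shown leave open whether going from isopropylcarbonyl to propanoyl on this core changes the number at all.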